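Trimming an Ethyl to Methyl on the Shared Core

The source may report more compounds than this note shows. Statements on the series, on what has been measured and on what is new or still open speak of the compounds shown alone.

Compound 2 `CCC(=O)N[C@@H]1CCCc2c1cncc2N1C(=O)c2ccc(Cl)cc2[C@H]1CC` carries an ethyl on the saturated ring carbon of the shared core and an ethyl in its amide. For the measured compounds named here, in an ADME assay on cells for inhibition of cytochrome P450 11B1, mitochondrial (Homo sapiens), read by HTRF (on this read-out lower numbers stand for stronger inhibition and higher numbers for weaker inhibition), compound 2 gives 10200 nM, the highest of the two numbers measured so far. Compound 1 `CC(=O)N[C@@H]1CCCc2c1cncc2N1C(=O)c2ccc(Cl)cc2[C@H]1C`, which bears a methyl at both places, gives 5140 nM in this assay; the two values lie within the scatter of each other, so no order can be read from them. Compound 3 `CCC(=O)N[C@@H]1CCCc2c1cncc2N1C(=O)c2ccc(Cl)cc2[C@H]1C` has not yet been measured and differs from compound 2 in one place: hydrogen in place of methyl on a saturated chain carbon bound to a saturated ring carbon. Going by the values given here, no pair of measured compounds isolates this change. Compound 1 at 5140 nM and compound 2 at 10200 nM leave little room for a large move in either direction. The step from compound 2 to compound 3 is therefore expected to be small, a 1.5-fold lower number from compound 2 to compound 3 (0.16 log units; within the scatter), not beyond the scatter. Compound 3 is estimated at 7000 nM, with a range from 3000 nM to 16000 nM.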

Compound 3, half-maximal inhibitory concentration: 9410 nM
Compound 3: the middle estimate sits 1.3-fold (0.13 log units) below what was measured; low and high end bracket the measured number.
By their numbers in this assay, from the lowest: compounds 1, 3 and 2 (each within the scatter of the next).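

Compound 3 lets the two places be read one at a time in this assay, which the earlier pair, differing in both, could not show. Ethyl to methyl on the saturated ring carbon gives a 1.1-fold lower number from compound 2 to compound 3 (0.04 log units; within the scatter), and methyl in place of hydrogen on a saturated chain carbon bound to a carbonyl carbon, which lengthens the amide chain, gives a 1.8-fold higher number from compound 1 to compound 3 (0.26 log units; within the scatter), so each single change stays within the scatter. No measurement is available here that would account for these results.

The compounds shown cover only methyl and ethyl at these two places. As far as these compounds go, whether a longer chain, a cyclopropyl ring or an amine at either place would give a step beyond the scatter remains open.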